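Deoxyuridine triazole series: trimming the aryl tail

The source may report more compounds than this note shows. Statements on the series, on what has been measured and on what is new or still open speak of the compounds shown alone.

Measured so far:
compound 1 `CC(C)(C)c1ccc(Cn2cc(-c3cn([C@H]4C[C@H](O)[C@@H](CO)O4)c(=O)[nH]c3=O)nn2)cc1` — 92.3%
compound 2 `CCCCc1ccc(-c2cc(-c3cn([C@H]4C[C@H](OC(C)=O)[C@@H](COC(C)=O)O4)c(=O)[nH]c3=O)on2)cc1` — 30.4%

In a functional assay on PC-3 cells (Homo sapiens) for cytotoxicity, read by sulforhodamine B assay, tested at 10 uM (a lower number here means less inhibition, a higher number more inhibition at the concentration tested (going by the name of the read-out)), compound 1 gives 92.3%, the highest of the two numbers shown; compound 2 gives 30.4%, a gap beyond the scatter. Compound 3 `O=c1[nH]c(=O)n([C@H]2C[C@H](O)[C@@H](CO)O2)cc1-c1cn(Cc2ccccc2)nn1` is not yet measured. Against compound 1 it carries one change, (hydrogen in place of tert-butyl on an aromatic carbon), which cut one bond further out reads 4-(tert-butyl)phenyl to phenyl. Going by the values given here, no step between measured compounds covers this change, so the expectation rests on compound 1 alone. A downward step beyond the scatter is expected, a number 37.3 percentage points lower from compound 1 to compound 3 (beyond the scatter). Compound 3 is estimated at 55% in this assay, with a range from 25% to 85%.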

Compound 3, a percentage reported as inhibition, at one concentration (the size of the read-out at that concentration, not a potency): 92.1%
The estimate for compound 3 lay 37.1 percentage points below the measured number; measured number above the stated range.
By their numbers in this assay, from the lowest: compound 2; then compounds 3 and 1 (each within the scatter of the next).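

In this assay hydrogen in place of tert-butyl on the aromatic carbon gives a number 0.2 percentage points lower from compound 1 to compound 3 (within the scatter) and so, at this one concentration, the tert-butyl group is not needed at this position to keep the read-out of compound 1. The plain phenyl of compound 3 serves as well here. Nothing measured accounts for this result.

Still open, as far as these compounds go, is whether an amine, a carboxylic acid or a longer chain on this carbon would hold the number. A read-out at one concentration is not a potency, so any difference between compound 1 and compound 3 in potency remains unresolved.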